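The compounds below may be only part of what the source reports. "The series", "measured", "known", "first", "only" and "open" are said of these compounds alone.

In an assay on HEK293 cells for displacement of a labelled ligand from adenosine receptor A2b (Homo sapiens), with a stated time of 30 min (on this read-out lower numbers stand for stronger inhibition and higher numbers for weaker inhibition), compound 1 `CC1=C(C(=O)OC(C)C)C(c2ccoc2)NC(=S)N1` gives 194 nM. Compound 3 `CC1=C(C(=O)OC(C)C)C(c2ccsc2)NC(=S)N1` differs from it in one place: thiophen-3-yl in place of furan-3-yl on a saturated ring carbon. In this assay compound 3 gives 416 nM. That change produced a 2.1-fold higher number from compound 1 to compound 3 (0.33 log units; beyond the scatter). Compound 2 `CCOC(=O)C1=C(C)N(C)C(=O)NC1c1ccoc1` has a different core, and the difference between the two cores is not broken down here. In this assay compound 2 gives 4260 nM, higher than both compound 1 and compound 3. Compound 4 `CCOC(=O)C1=C(C)N(C)C(=O)NC1c1ccsc1` has not yet been measured; it differs from compound 2 as follows: thiophen-3-yl in place of furan-3-yl on a saturated ring carbon. The surroundings are not identical, since in compound 2 the saturated ring carbon is next to the ring atom that bears an ethoxycarbonyl group, whereas in compound 1 it is next to the ring atom that bears an isopropoxycarbonyl group, so this is the same kind of change rather than the same change. A similar weakening is expected, a 2.1-fold higher number from compound 2 to compound 4 (0.32 log units; beyond the scatter), resting on a 2.1-fold higher number from compound 1 to compound 3 (0.33 log units; beyond the scatter). Compound 4 is therefore estimated at 9000 nM, expected to lie between 4000 nM and 20000 nM.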

Compound 4, inhibition constant: 2970 nM
Estimate against measurement, compound 4: 3.0-fold (0.48 log units) above, and the stated range ends above it.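

Replacing furan-3-yl with thiophen-3-yl gives a 1.4-fold lower number from compound 2 to compound 4 (0.16 log units; within the scatter) in this assay, so this pair shows no clear effect of the swap on the core of compound 2. The same change therefore did not carry over unchanged from the core of compound 1: the same change on two cores in this assay, a 2.1-fold higher number (0.33 log units; beyond the scatter) from compound 1 to compound 3 and a 1.4-fold lower number (0.16 log units; within the scatter) from compound 2 to compound 4, 3.1-fold (0.49 log units) apart, beyond the scatter of two such steps. Among these compounds, this shows that a step read on one core cannot simply be transferred to the other, but it does not show which difference between the cores matters, and each core offers only one pair.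

The compounds shown leave open whether an ethoxycarbonyl group on the core of compound 1 or an isopropoxycarbonyl group on the core of compound 2 would alter the step. They also leave open how a phenyl group or an amine would behave in place of furan-3-yl.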